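This account rests on a few compounds, and the source may have more. Where it says the series, first, only, none or still open, it means among the compounds named here.

The measured compounds and their numbers in an ADME assay on CCRF-CEM cells (Homo sapiens) for inhibition, read by fluorescence and resazurin assay, with a stated time of 72 h; on this read-out lower numbers stand for stronger inhibition of growth and higher numbers for weaker inhibition of growth:
compound 1, `N[C@H]1CC[C@H](Nc2nc(Nc3ccc(-n4cccn4)cc3)c3ncn(C4CCCC4)c3n2)CC1`, gives 933 nM;
compound 2, `N[C@H]1CC[C@H](Nc2nc(Nc3ccc(-n4cncn4)cc3)c3ncn(C4CCCC4)c3n2)CC1`, gives 871 nM;
compound 3, `N[C@H]1CC[C@H](Nc2nc(Nc3ccc(-c4ccoc4)nc3)c3ncn(C4CCCC4)c3n2)CC1`, gives 619 nM.

Compound 3 has the lowest of the three numbers, but the gaps are small: a 1.5-fold lower number from compound 1 to compound 3 (0.18 log units; within the scatter), a 1.4-fold lower number from compound 2 to compound 3 (0.15 log units; within the scatter), and likewise a 1.1-fold lower number from compound 1 to compound 2 (0.03 log units; within the scatter). All three sit within the usual scatter of one another, so none can be called stronger than another.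

Compound 4, `COc1ccc(-c2ccc(Nc3nc(N[C@H]4CC[C@H](N)CC4)nc4c3ncn4C3CCCC3)cn2)cc1`, differs from compound 3 in one place: 4-methoxyphenyl in place of furan-3-yl on an aromatic carbon. The two steps that reach compound 3, from compound 1 and from compound 2, exchanged the whole group on the aromatic nitrogen and stayed within the scatter. For the measured compounds named here, no measured step alters only the group on the six-membered aromatic ring with one nitrogen, so the expectation rests on those two. Compound 4 is therefore expected to stay close to compound 3, with a 1.1-fold higher number from compound 3 to compound 4 (0.02 log units; within the scatter) within the scatter. The estimate for compound 4 in this assay is 650 nM, in a range from 250 nM to 1700 nM.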

Compound 4, concentration for 50% growth inhibition: 544 nM
For compound 4 the middle estimate is 1.2-fold (0.08 log units) above the measured one, and the stated range covers the measured number.
By their numbers in this assay, from the lowest: compounds 4, 3, 2 and 1 (each within the scatter of the next).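

For the compounds shown here, this is the first measured step that alters only the group on an aromatic carbon of the six-membered aromatic ring with 1 nitrogen, and in this assay it stays within the scatter (a 1.1-fold lower number from compound 3 to compound 4 (0.06 log units; within the scatter)). Furan-3-yl and the larger 4-methoxyphenyl therefore cannot be told apart at this position, whether the ring is five-membered or six-membered. Nothing at hand explains this result.

Both groups are aromatic rings. Going by these compounds, whether a carboxylic acid or an amine at this position would stay within the scatter of compound 3 remains open.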